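Chain ends on the shared core: carbamoyl to hydroxymethyl

The source may report more compounds than this note shows. Statements on the series, on what has been measured and on what is new or still open speak of the compounds shown alone.

Measured in a functional assay (trachea) with Cavia porcellus as the target; a higher number here means that more compound is needed for the effect, a lower number that less compound is needed:
- compound 1 `C=CCCn1c(=O)c2[nH]cnc2n(CCC)c1=O`: 200 nM
- compound 2 `CCCn1c(=O)n(CC(=O)O)c(=O)c2[nH]cnc21`: 41000 nM
- compound 3 `CCCn1c(=O)n(CCC(N)=O)c(=O)c2[nH]cnc21`: 13100 nM

Not yet measured: compound 4 `CCCn1c(=O)n(CCCO)c(=O)c2[nH]cnc21`

Of the three numbers, compound 3 has the second highest at 13100 nM. Going on to compound 4, hydroxymethyl takes the place of carbamoyl on a saturated chain carbon, two bonds along the chain from an aromatic nitrogen: hydroxymethyl in place of carbamoyl on a saturated chain carbon, two bonds along the chain from an aromatic nitrogen. The closest evidence is the large step of a 66-fold higher number from compound 1 to compound 3 (1.82 log units; beyond the scatter), which has carbamoyl in place of vinyl at this same place. The modest step of a 3.1-fold lower number from compound 2 to compound 3 (0.50 log units; beyond the scatter) shows a smaller spread among the two high numbers. For the measured compounds named here, no measured compound carries hydroxymethyl here, so the size of the step remains uncertain. Part of the large step to compound 3 is expected to be recovered, but not all of it. A moderate step to a lower number is expected in this assay: a 3.7-fold lower number from compound 3 to compound 4 (0.57 log units; beyond the scatter). For compound 4 the estimate is 3500 nM, with an expected range of 900 nM to 14000 nM.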

Compound 4, half-maximal effective concentration: 5100 nM
Beside the measured number, compound 4's estimate is 1.5-fold (0.16 log units) below it; the range from low to high includes it.
By their numbers in this assay, from the lowest: compound 1; then compound 4; then compound 3; then compound 2.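

In this assay, swapping the chain end among these polar groups moves the number far less than leaving the vinyl end does: a 2.6-fold lower number from compound 3 to compound 4 (0.41 log units; beyond the scatter), whereas a 26-fold higher number from compound 1 to compound 4 (1.41 log units; beyond the scatter). The carboxy end remains the least favourable of the series, with an 8.0-fold lower number from compound 2 to compound 4 (0.91 log units; beyond the scatter), so hydroxymethyl recovers only part of the ground lost with carbamoyl, and compound 2, compound 3 and compound 4 all keep higher numbers than compound 1. Nothing measured here bears on why the chain ends fall in this order.

From the compounds shown here alone, it remains open whether an amine or a methyl ether at the chain end would fall with these three or nearer compound 1. Going by these compounds, it is equally open how a longer chain ending in hydroxyl, or a plain propyl chain, would compare with the 3-hydroxypropyl chain of compound 4.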